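This account rests on a few compounds, and the source may have more. Where it says the series, first, only, none or still open, it means among the compounds named here.

Measured so far, in an assay on membranes from liver for displacement of a labelled ligand from Sigma intracellular receptor 2 (Rattus norvegicus), read by scintillation counting, with a stated time of 120 min, in the presence of a further agent that is not named here; on this read-out higher numbers stand for weaker inhibition and lower numbers for stronger inhibition:

Compound 1 `CN(Cc1ccccc1)C1CCc2ccsc2CC1` gives 91 nM.
Compound 2 `CN(CCCc1ccccc1)C1CCc2ccsc2CC1` gives 13 nM.

Of these two numbers, compound 1 carries the higher one, which on this read-out means the weaker binding of the pair; compound 2 gives a lower number, and the gap between the two is beyond the usual scatter of repeated measurements. Compound 3 `CCN(Cc1ccccc1)C1CCc2ccsc2CC1` has not yet been measured. It differs from compound 1 in one place only: methyl in place of hydrogen on a saturated chain carbon bound to an amine nitrogen. Going by the values given here, no measured pair of compounds shows this same change, so there is no measured step to lean on. Compound 2 differs from compound 1 elsewhere, in the chain that carries the phenyl ring, and says nothing direct about a methyl added here. With nothing measured on this change, the expectation for compound 3 is a step of about a 1.2-fold lower number from compound 1 to compound 3 (0.08 log units; within the scatter) from compound 1, which is within the scatter, and no shift in a clear direction. Compound 3 is therefore estimated at 75 nM in this assay, with a range from 25 nM to 220 nM.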

Compound 3, inhibition constant: 149 nM
Beside the measured number, compound 3's estimate is 2.0-fold (0.30 log units) below it, and the stated range covers the measured number.
By their numbers in this assay, from the lowest: compound 2; then compounds 1 and 3 (each within the scatter of the next).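

In this assay, methyl in place of hydrogen on a saturated chain carbon bound to an amine nitrogen gives a 1.6-fold higher number from compound 1 to compound 3 (0.21 log units; within the scatter), which lies within the scatter. Going by these compounds alone, this is the first measured step at this position, since compound 1 and compound 2 differ only in the chain that carries the phenyl ring: in this one pair, methyl to ethyl on the amine nitrogen gives no change that this read-out can separate from the noise of repeated measurements. No supporting evidence accompanies this step, so the result stays a plain observation with no explanation attached.

As far as these compounds go, one step cannot show how far this tolerance extends, so it remains open whether a longer chain such as propyl, a branched group such as isopropyl, or a plain hydrogen on the amine nitrogen would also stay within the scatter. From the compounds shown here alone, it is also open whether the same change made on compound 2, with its longer chain to the phenyl ring, would give a step of similar size.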